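The source may report more compounds than this note shows. Statements on the series, on what has been measured and on what is new or still open speak of the compounds shown alone.

Measured so far:
compound 1 `Cc1cccc(-n2cc(-c3ccc(/C=C4\C(=O)Nc5ccccc54)cc3)nn2)c1`: 4690 nM
compound 2 `O=C1Nc2ccccc2/C1=C/c1ccc(-c2cn(-c3ccccc3F)nn2)cc1`: 12500 nM

Both compounds share the same core and differ only in the group on an aromatic nitrogen. Among the measured compounds shown here, in a functional assay on MKN-45 cells (Homo sapiens) for inhibition, read by CCK-8 assay, with a stated time of 24 h (on this read-out lower numbers stand for stronger inhibition and higher numbers for weaker inhibition), compound 1 gives 4690 nM, and compound 2 gives 12500 nM, the highest of the two numbers; the only measured step is a 2.7-fold higher number from compound 1 to compound 2 (0.43 log units; beyond the scatter).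

Compound 3 `O=C1Nc2ccccc2/C1=C/c1ccc(-c2cn(-c3ccc(Cl)c(C(F)(F)F)c3)nn2)cc1` has not yet been measured. It differs from compound 2 in this way: 4-chloro-3-(trifluoromethyl)phenyl in place of 2-fluorophenyl on an aromatic nitrogen. For the measured compounds named here, the one measured step bears on it only loosely, since it shows that swapping the group on this aromatic nitrogen moves the number beyond the scatter, without telling which way a third group would go. A moderate change in either direction is therefore expected. For compound 3 the estimate in this assay is 7000 nM, with a range from 2000 nM to 25000 nM, which corresponds to an expected step of a 1.8-fold lower number from compound 2 to compound 3 (0.25 log units; within the scatter).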

Compound 3, half-maximal inhibitory concentration: 8890 nM
Beside the measured number, compound 3's estimate is 1.3-fold (0.10 log units) below it, within the range that was stated.
By their numbers in this assay, from the lowest: compounds 1, 3 and 2 (each within the scatter of the next, the first and the last beyond it).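

In this assay, replacing 2-fluorophenyl by 4-chloro-3-(trifluoromethyl)phenyl gives a 1.4-fold lower number from compound 2 to compound 3 (0.15 log units; within the scatter). So this aromatic nitrogen accepts a bigger group carrying both chlorine and fluorine without a clear shift in the number, and the same holds against the 3-methylphenyl group, with a 1.9-fold higher number from compound 1 to compound 3 (0.28 log units; within the scatter). Compound 3 thus lies within the scatter of both earlier compounds, and no available evidence explains these numbers.

All three groups shown place a six-membered aromatic ring of carbon on this nitrogen, so it remains open how the number would respond to a saturated ring or a longer chain there. From the compounds shown here alone, the effect of an amine or a carboxylic acid on the phenyl ring also remains open.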